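A few compounds are considered here, and "the series" means these few. Any claim that something is new, unique, unknown or untested is made for them only; others in the source may bear on it.

Measured so far:
- compound 1 `OC[C@@H]1[C@@H](O)[C@H](O)[C@@H](O)CN1CCCCCCOc1cc(F)ccc1F`: > 500000 nM
- compound 2 `OC[C@@H]1[C@@H](O)[C@H](O)[C@@H](O)CN1CCCCCCOc1cccc(C(F)(F)F)c1`: > 500000 nM
- compound 3 `OC[C@@H]1[C@@H](O)[C@H](O)[C@@H](O)CN1CC/C=C\CCOc1cc(F)ccc1F`: > 500000 nM

These results come from an ADME assay on MDBK cells (Bos taurus) for cytotoxicity, read by MTT assay; on this read-out higher numbers stand for lower toxicity in this test and lower numbers for higher toxicity in this test. Compound 1 gives > 500000 nM, which is a limit and not a number. It stands at the limit of > 500000 nM in this assay, at which 3 of the 3 values shown sit.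

Compound 4 `CCC1CCCCC1OCCCCCCN1C[C@H](O)[C@@H](O)[C@H](O)[C@H]1CO` differs from compound 1 in one place: a group of 8 heavy atoms (8 carbon; one six-membered non-aromatic ring of carbon only) in place of a group of 8 heavy atoms (6 carbon, 2 fluorine; one six-membered aromatic ring of carbon only), on an oxygen on a saturated carbon. Within the data shown here, no measured pair shows what this exchange does in this assay. A small step toward lower numbers is therefore expected, perhaps none beyond the scatter. The estimated change is an at least 1.6-fold lower number from compound 1 to compound 4 (0.22 log units; that floor lies within the scatter). The expected value for compound 4 is 300000 nM, with an estimated range of 100000 nM to 900000 nM.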

Compound 4, half-maximal cytotoxic concentration: 450000 nM
The estimate for compound 4 lay 1.5-fold (0.18 log units) below the measured number; measured number inside the range.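

In this assay compound 4 is the first compound shown to give a number and not a limit, 450000 nM. Placing the saturated ring group of 8 carbon on this oxygen in place of 2,5-difluorophenyl gives an at least 1.1-fold lower number from compound 1 to compound 4 (0.04 log units; that floor lies within the scatter). That step is only a floor, as the value of compound 1 is a limit of the assay: the limit of > 500000 nM in this assay, at which 3 of the 4 values shown sit.

The compounds shown leave open what an amine or a carboxylic acid in place of this ring group would give in this assay, and what a longer chain would give.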